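A few compounds are considered here, and "the series" means these few. Any claim that something is new, unique, unknown or untested is made for them only; others in the source may bear on it.

Measured compounds in a functional assay on HEK293 cells for agonist activity at D(4) dopamine receptor (Homo sapiens), read by FLIPR; on this read-out lower numbers stand for smaller maximal responses and higher numbers for larger maximal responses:

Compound 1, `CCc1cccc(NC(=O)CN2CCC(c3cccc[n+]3[O-])CC2)c1`, gives 62%.
Compound 2, `O=C(NCN1CCC(c2cccc[n+]2[O-])CC1)c1cnccc1Cl`, gives 44%.
Compound 3, `Oc1ccc(N2CCN(Cc3nc4ccccc4[nH]3)CC2)nc1`, gives 70%.

Among these three, compound 1 holds the second highest reading. Its nearest neighbour is compound 3, whose reading of 70% lies within the usual scatter of compound 1, so the two cannot be told apart. The furthest is compound 2, whose reading of 44% lies beyond the scatter below compound 1.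

Compound 4, `O=C(CN1CCC(c2cccc[n+]2[O-])CC1)Nc1cccc(Cl)c1`, has not yet been measured. It differs from compound 1 in one place: chloro in place of ethyl on an aromatic carbon. Within the data shown here, no pair of measured compounds differs only in this way, so there is no measured step to lean on. The rest of the molecule, including the amide link and the charged ring on the piperidine, is unchanged, and a swap of one small neutral group for another on the same aromatic carbon is expected to move the response little, if at all beyond the scatter. The expected step is a number 2 percentage points lower from compound 1 to compound 4 (within the scatter). Compound 4 is therefore estimated at 60%, with a range from 45% to 75%.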

Compound 4, largest response reached (reported as efficacy), in percent of the reference or control that the assay uses: 76%
The estimate for compound 4 lay 16 percentage points below the measured number; measured number above the stated range.
By their numbers in this assay, from the lowest: compound 2; then compounds 1, 3 and 4 (each within the scatter of the next, the first and the last beyond it).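

In this assay, the change from 3-ethylphenyl to 3-chlorophenyl gives a number 14 percentage points higher from compound 1 to compound 4 (beyond the scatter), with the rest of the molecule unchanged. Among these compounds, this shows that the maximal response can shift beyond the usual scatter when one small group with no net charge replaces another at this aromatic carbon, which no earlier pair could show. Nothing shown explains why chloro and ethyl differ here.

This is a single pair, so it sets no trend for the position. From the compounds shown here alone, whether a methoxy group, a fluorine atom, an amine or a carboxylic acid on the same carbon would give a response closer to compound 1 or to compound 4 stays open, as does whether the same swap would have a similar effect on a different core.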